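Methyl for trifluoromethyl on the triazole aryl ring

The compounds below may be only part of what the source reports. "The series", "measured", "known", "first", "only" and "open" are said of these compounds alone.

Compound 2 `C=C1C(=O)[C@]23C[C@@]1(O)CC[C@H]2c1ccc(O)c(C)c1[C@@H]3Cn1cc(-c2ccc(C(F)(F)F)cc2)nn1` gives 1840 nM in a functional assay on MCF7 cells (Homo sapiens) for cytotoxicity, read by MTT assay, with a stated time of 4 days; a lower number here means a stronger inhibitor, a higher number a weaker inhibitor. Among the compounds with values here, it is the only compound with a number in this assay; the other value is a limit. Compound 1 `C=C1C[C@]23C[C@@]1(O)CC[C@H]2c1ccc(OS(=O)(=O)c2ccc(C)cc2)c(C)c1[C@@H]3Cn1cc(-c2ccc(C)cc2)nn1` sits at the limit > 20000 nM in this assay, which is a limit and not a number (the limit of > 20000 nM in this assay, at which 1 of the 2 values shown sits). Within the data shown here, compound 1 and compound 2 differ in more than one place, so their two values show only that compound 2 has a number where compound 1 has none.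

Compound 3 `C=C1C(=O)[C@]23C[C@@]1(O)CC[C@H]2c1ccc(O)c(C)c1[C@@H]3Cn1cc(-c2ccc(C)cc2)nn1` is not yet measured. Against compound 2 the change is methyl in place of trifluoromethyl on an aromatic carbon. Among the measured compounds shown here, no measured pair isolates this change, so the expected step is small: the step of a 1.4-fold higher number from compound 2 to compound 3 (0.13 log units; within the scatter) is estimated to lie within the scatter, with no clear direction. Compound 3 is expected to give about 2500 nM in this assay, within 900 nM to 7000 nM.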

Compound 3, half-maximal inhibitory concentration: 370 nM
The estimate for compound 3 lay 6.8-fold (0.83 log units) above the measured number; the whole stated range lies above it.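

The aromatic carbon para to a large group now has a reading of its own in this assay: methyl in place of trifluoromethyl gives a 5.0-fold lower number from compound 2 to compound 3 (0.70 log units; beyond the scatter). This is the only pair shown that differs in one place, so the position can be shown to affect the number, and of the two groups the 4-methylphenyl compound has the lower number. Nothing measured in this series accounts for the step.

Two groups at one carbon fix no trend, and a single pair cannot show whether the same step would hold with another part of the shared core changed. On these data alone, whether hydrogen, a methoxy group, an amine or a carboxylic acid at this carbon would give a lower or a higher number stays open.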